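Amine-bearing amide replacing the hydroxypyrrolidine: cytotoxicity notes

A few compounds are considered here, and "the series" means these few. Any claim that something is new, unique, unknown or untested is made for them only; others in the source may bear on it.

Compound 1 `COc1ccc(/C=C\c2cc(OC)c(OC)c(OC)c2)cc1OCc1ccc(CN2CCCC[C@H]2C(=O)O)cc1`: > 50000 nM, a limit of the assay
Compound 2 `COc1ccc(/C=C\c2cc(OC)c(OC)c(OC)c2)cc1OCc1ccc(CN2CC[C@H](O)C2)cc1`: 51000 nM

Among the compounds with values here, in an ADME assay on NCM460 cells (Homo sapiens) for cytotoxicity, read by CCK-8 assay, with a stated time of 48 h (a lower number here means a stronger inhibitor, a higher number a weaker inhibitor), compound 2 gives 51000 nM, the only number so far. Compound 1 carries (the limit of > 50000 nM in this assay, at which 1 of the 2 values shown sits). Within the data shown here, the one measured step is therefore a step that the limit leaves unreadable from compound 1 to compound 2, and it offers no size to carry forward.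

The next structure is compound 3 `COc1ccc(/C=C\c2cc(OC)c(OC)c(OC)c2)cc1OCc1ccc(CN2CCCCC2C(=O)NCCN)cc1`. It differs from compound 2 as follows: 2-((2-aminoethyl)carbamoyl)piperidin-1-yl in place of 3-hydroxypyrrolidin-1-yl on a saturated chain carbon bound to an aromatic carbon.

With no readable step available, the expectation rests on compound 2 alone at 51000 nM, and no step beyond the scatter is expected in either direction. The estimated change is a 1.3-fold lower number from compound 2 to compound 3 (0.11 log units; within the scatter). In this assay compound 3 is expected at 40000 nM, with an estimated range of 12000 nM to 90000 nM.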

Compound 3, half-maximal inhibitory concentration: > 50000 nM
Compound 3 gave a limit, no number; the forecaster's own chance of this, stated with the estimate: 35%; at least 1.2-fold (0.09 log units) between middle value and limit.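

Compound 3 gives only a limit in this assay, so no step among compound 1, compound 2 and compound 3 can be read: the limit of > 50000 nM in this assay, at which 2 of the 3 values shown sit.

The compounds shown leave open whether any change on this saturated chain carbon shifts the reading in this assay at all.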